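Methoxy for chloro on the aryl group of a triazole indole

The compounds below may be only part of what the source reports. "The series", "measured", "known", "first", "only" and "open" are said of these compounds alone.

Measured compounds: compound 1 `COc1ccc(-c2[nH]c3cc(F)ccc3c2Cn2ccnc2)cc1` gives 36.1 nM; compound 2 `Fc1ccc(-c2[nH]c3cc(F)ccc3c2Cn2cncn2)cc1` gives 54.4 nM; compound 3 `Fc1ccc2c(Cn3cncn3)c(-c3ccc(Cl)cc3)[nH]c2c1` gives 217 nM.

In an assay on isolated protein for inhibition of Aromatase (Homo sapiens), read by ELISA, using NADPH, with a stated time of 24 h (on this read-out lower numbers stand for stronger inhibition and higher numbers for weaker inhibition), compound 3 stands highest of the three numbers, beyond the scatter from compound 2 and further still from compound 1. Compound 4 `COc1ccc(-c2[nH]c3cc(F)ccc3c2Cn2cncn2)cc1` differs from compound 3 by methoxy in place of chloro on an aromatic carbon. For the measured compounds named here, no measured step covers this exact exchange. Going by the values given here, the only step within the same pair of rings, a 4.0-fold higher number from compound 2 to compound 3 (0.60 log units; beyond the scatter), shows the chloro compound as the weaker one. Compound 1, which also carries the 4-methoxyphenyl group, gives 36.1 nM. Compound 4 is therefore expected to move to a lower number, a 3.6-fold lower number from compound 3 to compound 4 (0.56 log units; beyond the scatter). The estimate for compound 4 in this assay is 60 nM, with a range from 25 nM to 150 nM.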

Compound 4, half-maximal inhibitory concentration: 14.1 nM
Beside the measured number, compound 4's estimate is 4.3-fold (0.63 log units) above it, and the stated range ends above it.
By their numbers in this assay, from the lowest: compound 4; then compounds 1 and 2 (each within the scatter of the next); then compound 3.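

In this assay, methoxy on this aromatic carbon gives the lower number against both halogens, with a 15-fold lower number from compound 3 to compound 4 (1.19 log units; beyond the scatter) and a 3.9-fold lower number from compound 2 to compound 4 (0.59 log units; beyond the scatter). With the 4-methoxyphenyl group held constant, the other end of the molecule also matters, since 1H-1,2,4-triazol-1-yl in place of 1H-imidazol-1-yl gives a 2.6-fold lower number from compound 1 to compound 4 (0.41 log units; beyond the scatter). No measurement at hand accounts for these steps. Open, on these data alone, is whether an ethoxy group or an amine at this place would match methoxy. Also open, as far as these compounds go, is whether the exchange of chloro for methoxy would run the same way with 1H-imidazol-1-yl in the molecule.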